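Thioether-linked amides against IL15 receptor binding

This account rests on a few compounds, and the source may have more. Where it says the series, first, only, none or still open, it means among the compounds named here.

Measured so far:
compound 1 `Cn1c(Cc2nn(C)c(=O)c3ccccc23)nnc1SCCCCCCCCCCCCCCCC(=O)Nc1ccc(Cl)cc1Cl` — 7300 nM
compound 2 `Cn1c(Cc2nn(C)c(=O)c3ccccc23)nnc1SCCCCCC(=O)Nc1ccc(Cl)cc1Cl` — 4100 nM
compound 3 `CC(C)COc1ccc(NC(=O)CSc2nnc(Cc3nn(C)c(=O)c4ccccc34)n2C)cc1` — 30000 nM

Of the compounds shown here, three sharing one core have been tested in an assay on isolated protein (Mus musculus) for inhibition of IL15-IL15 receptor (Homo sapiens), read by resazurin assay, with stated times of 30 min and 2.5 days; a higher number here means a weaker inhibitor, a lower number a stronger inhibitor. Compound 2 gives 4100 nM, the lowest of the three numbers. Its chain differs from that of compound 2, and compound 1 gives 7300 nM; the gap between the two lies within the scatter, so nothing can be said about which is the stronger inhibitor. Compound 3 gives 30000 nM, a gap to compound 2 that lies beyond the scatter.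

The next compound, compound 4 `Cn1c(Cc2nn(C)c(=O)c3ccccc23)nnc1SCCCCCCCC(=O)Nc1ccccc1O`, has not been measured. It differs from compound 2 by 2-((2-hydroxyphenyl)carbamoyl)ethyl in place of (2,4-dichlorophenyl)carbamoyl on a saturated chain carbon, five bonds along the chain from a sulfur. Going by the values given here, no single-point step between measured compounds is recorded, so there is no measured anchor for this change. The chain and the aryl amide both change at once, and the only aryl variation seen, in compound 3, comes together with a different chain, so its effect cannot be separated.

Compound 4 is therefore expected to land near compound 2, with an estimated step of a 1.5-fold higher number from compound 2 to compound 4 (0.17 log units; within the scatter) that stays within the scatter. Compound 4 is estimated at 6000 nM, between 2000 nM and 25000 nM.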

Compound 4, half-maximal inhibitory concentration: 27000 nM
Estimate against measurement, compound 4: 4.5-fold (0.65 log units) below; measured number outside the range, above it.
By their numbers in this assay, from the lowest: compounds 2 and 1 (each within the scatter of the next); then compounds 4 and 3 (each within the scatter of the next).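

In this assay, going by these compounds alone, the exchange of (2,4-dichlorophenyl)carbamoyl for 2-((2-hydroxyphenyl)carbamoyl)ethyl on a saturated chain carbon, five bonds along the chain from a sulfur, gives a 6.6-fold higher number from compound 2 to compound 4 (0.82 log units; beyond the scatter), the first step in this set between compounds that differ in one place. It shows that this place is not indifferent to what it carries: this exchange yields a weaker inhibitor, by a margin that the scatter of the measurement does not cover. No measurement shown here bears on why the number rises.

The exchange alters the chain and the aryl amide together, so the compounds shown leave open how much of the step belongs to the added chain carbons and how much to the loss of the two chlorines or the gain of the hydroxyl group. They also leave open how the same place would read in this assay with a carboxylic acid, a primary amine or a pyridyl amide at the end of the chain.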